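Losing one side group from compound 2

This account rests on a few compounds, and the source may have more. Where it says the series, first, only, none or still open, it means among the compounds named here.

Compound 1 `CC(C)[C@H](N)C(=O)OC[C@H]1O[C@@H](n2cc(F)c(=O)[nH]c2=O)C[C@@H]1O` gives 0.188 h
Compound 2 `CC(C)[C@H](N)C(=O)OC[C@H]1O[C@@H](n2cc(F)c(=O)[nH]c2=O)C[C@@H]1OC(=O)[C@@H](N)C(C)C` gives 0.14 h
Compound 3 `N[C@@H](CCC(=O)OC[C@H]1O[C@@H](n2cc(F)c(=O)[nH]c2=O)C[C@@H]1O)C(=O)O` gives 0.335 h

In an ADME assay on tissue (MIA PaCa-2 cells, Homo sapiens) for pharmacokinetics (on this read-out lower numbers stand for a shorter-lived compound and higher numbers for a longer-lived compound), compound 2 gives 0.14 h and so sits within the scatter of compound 1, while compound 3 stands higher, beyond the scatter. Compound 4 `CC(C)[C@H](N)C(=O)O[C@H]1C[C@H](n2cc(F)c(=O)[nH]c2=O)O[C@@H]1CO` differs from compound 2 by one change: hydrogen in place of (1-amino-2-methylpropyl)carbonyl on an oxygen on a saturated carbon with hydrogen in place of (1-amino-2-methylpropyl)carbonyl on an oxygen on a saturated carbon. The closest measured evidence is a 1.3-fold lower number from compound 1 to compound 2 (0.13 log units; within the scatter) and it concerns the same group on another oxygen. The second measured step, a 1.8-fold higher number from compound 1 to compound 3 (0.25 log units; within the scatter) on the other hand, alters the group itself. Both steps are modest, but neither tests this particular oxygen, so the forecast remains uncertain. The expected change is a 1.8-fold higher number from compound 2 to compound 4 (0.25 log units; within the scatter) and this estimate stays small. In this assay compound 4 is estimated at 0.25 h with an expected range from 0.1 h to 0.6 h for repeated measurements.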

Compound 4, half-life: 0.203 h
The estimate for compound 4 lay 1.2-fold (0.09 log units) above the measured number, and the stated range covers the measured number.
By their numbers in this assay, from the lowest: compounds 2, 1, 4 and 3 (each within the scatter of the next, the first and the last beyond it).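

Taking the (1-amino-2-methylpropyl)carbonyl off this oxygen, which leaves a hydroxymethyl in place of the ester, gives a 1.5-fold higher number from compound 2 to compound 4 (0.16 log units; within the scatter) in this assay. Until now, only the group on the other oxygen had been tested, through a 1.3-fold lower number from compound 1 to compound 2 (0.13 log units; within the scatter); the new step shows that removing the group from this oxygen also leaves the half-life within the scatter, so neither single step separates the two compounds it joins. No measurement shown here explains the size of this step.

The compounds shown leave open how the half-life would respond if this oxygen carried a plain acetyl or a benzoyl, groups without an amine. They also leave open whether a 3-amino-3-carboxypropyl carbonyl on the other oxygen would behave as it does on the hydroxymethyl oxygen.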